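Hydroxy to cyano: working notes on the series

The compounds below may be only part of what the source reports. "The series", "measured", "known", "first", "only" and "open" are said of these compounds alone.

compound 1 `COc1ccc(S(=O)(=O)N2CCc3cccc(-c4ccc([N+](=O)[O-])cc4)c32)cc1`: 53.1 nM
compound 2 `COc1ccc(S(=O)(=O)N2CCc3cccc(-c4ccncc4)c32)cc1`: 101 nM
compound 3 `COc1ccc(S(=O)(=O)N2CCc3cccc(-c4ccc(O)cc4)c32)cc1`: 114 nM

In a functional assay on NCI-H460 cells (Homo sapiens) for inhibition, with a stated time of 72 h (a higher number here means a weaker inhibitor, a lower number a stronger inhibitor), compound 3 gives 114 nM. The measured steps that reach it are a 1.1-fold higher number from compound 2 to compound 3 (0.05 log units; within the scatter) and a 2.1-fold higher number from compound 1 to compound 3 (0.33 log units; beyond the scatter). The remaining step is a 1.9-fold higher number from compound 1 to compound 2 (0.28 log units; within the scatter). Compound 4 `COc1ccc(S(=O)(=O)N2CCc3cccc(-c4ccc(C#N)cc4)c32)cc1` carries cyano in place of hydroxy on an aromatic carbon, para to a large group: cyano in place of hydroxy on an aromatic carbon. Going by the values given here, no measured compound carries cyano, so the guidance is indirect. Among the compounds with values here, the nearest guide is hydroxy in place of nitro, the one step beyond the scatter, at a 2.1-fold higher number from compound 1 to compound 3 (0.33 log units; beyond the scatter). Reversing that exchange, a small step to a lower number is expected in this assay, no larger than that one. The expected step is a 1.6-fold lower number from compound 3 to compound 4 (0.21 log units; within the scatter). For compound 4 the estimated value is 70 nM, with an expected range of 30 nM to 150 nM.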

Compound 4, half-maximal inhibitory concentration: 29.5 nM
The estimate for compound 4 lay 2.4-fold (0.38 log units) above the measured number; the measured number lies below the stated range.
By their numbers in this assay, from the lowest: compounds 4, 1, 2 and 3 (each within the scatter of the next, the first and the last beyond it).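

In this assay, going by these compounds alone, cyano, on an aromatic carbon para to a large group, gives a 3.9-fold lower number from compound 3 to compound 4 (0.59 log units; beyond the scatter) and, set against pyridin-4-yl, gives a 3.4-fold lower number from compound 2 to compound 4 (0.53 log units; beyond the scatter); both steps exceed any among the earlier compounds. Cyano in place of nitro gives a 1.8-fold lower number from compound 1 to compound 4 (0.26 log units; within the scatter), so these two groups are not separated at this position. No available evidence bears on the origin of these steps.

From the compounds shown here alone, whether an amine or a carboxylic acid at this place would track cyano or hydroxy remains open.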